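The source may hold more compounds than are shown below. What is called first, only, known or untested is meant among the compounds shown, and "the series" means these compounds.

Measured so far in an assay on isolated protein for binding affinity to 5-hydroxytryptamine receptor 1E (Homo sapiens); a lower number here means a stronger inhibitor, a higher number a weaker inhibitor: compound 1 `COc1ccccc1-c1cc(C2CCNC2)ccc1Cl` gives 770 nM. Compound 2 `CCNCc1ccc(Cl)c(-c2ccccc2OC)c1` gives > 10000 nM, which is a limit of this assay and not a number.

Compound 2 therefore sits at the limit of > 10000 nM in this assay, at which 1 of the 2 values shown sits. Compound 3 `CCCCNCc1ccc(Cl)c(-c2ccccc2OC)c1` carries ethyl in place of hydrogen on a saturated chain carbon, two bonds along the chain from an amine nitrogen. For the measured compounds named here, the one measured step, an at least 12-fold higher number from compound 1 to compound 2 (1.11 log units; beyond the scatter), concerns a different part of the structure and gives no direct guide to lengthening the chain; it only shows how far compound 2 already lies from compound 1. The step expected here is a step that the limit leaves unreadable from compound 2 to compound 3, most likely ending again in a limit. Compound 3 is estimated at 15000 nM, with a range of 4000 nM to 60000 nM.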

Compound 3, inhibition constant: > 10000 nM
Compound 3 gave a limit, no number; the forecaster's own chance of this, stated with the estimate: 70%; the middle value does not contradict the limit.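

With butylamino in place of ethylamino, the open chain still leaves the series far from the pyrrolidin-3-yl compound, with an at least 12-fold higher number from compound 1 to compound 3 (1.11 log units; beyond the scatter). Going from ethylamino to butylamino therefore brings no recovery that can be seen in this assay. The step between compound 2 and compound 3 cannot be read, because both ends are limits and not numbers: the limit of > 10000 nM in this assay, at which 2 of the 3 values shown sit.

Open remains how either chain ranks beyond the limit. Also open, on these data alone, is whether a methylamino or benzylamino group in place of butylamino would give a readable number.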